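The source may hold more compounds than are shown below. What is called first, only, known or untested is meant among the compounds shown, and "the series" means these compounds.

Measured so far: compound 1 `O=C(/C=C/c1ccccc1)c1ccc(N2CCN(c3cccc(Cl)c3)CC2)cc1` gives 14.1%; compound 2 `O=C(/C=C/c1ccc(Cl)cc1)c1ccc(N2CCN(S(=O)(=O)c3ccc(C(F)(F)F)cc3)CC2)cc1` gives 59.6%.

In a functional assay on the whole organism (strain Kunming) for inhibition, with Mus musculus as the target, with a stated time of 1 h, at a dose of 40 mg/kg by the oral route (on this read-out higher numbers stand for more inhibition at the one dose given (going by the name of the read-out) and lower numbers for less inhibition), compound 1 is the lower of the two measured compounds, and the gap up to compound 2 lies beyond the usual scatter. Going by the values given here, compound 2 differs from compound 1 in more than one place, so no single step between them can be drawn out.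

Compound 3 `Cc1ccc(S(=O)(=O)N2CCN(c3ccc(C(=O)/C=C/c4ccccc4)cc3)CC2)cc1` has not yet been tested in this assay. Compared with compound 1 it shows one change: (4-methylphenyl)sulfonyl in place of 3-chlorophenyl on an amine nitrogen in a ring. Among the compounds with values here, compound 2 also carries a sulfonyl group on that ring nitrogen, and its value of 59.6% is the higher of the two numbers known. On that basis the step from compound 1 to compound 3 is expected to be upward and beyond the scatter, about a number 30.9 percentage points higher from compound 1 to compound 3 (beyond the scatter). For compound 3 the estimated value in this assay is 45%, with a range from 25% to 65%.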

Compound 3, a percentage reported as inhibition, in the whole organism at one dose (the size of the read-out at that dose, not a potency): 30.8%
Compound 3: the middle estimate sits 14.2 percentage points above what was measured, within the range that was stated.
By their numbers in this assay, from the lowest: compound 1; then compound 3; then compound 2.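

In this assay, the earlier pair differed in more than one place, whereas here a change on the amine nitrogen in the ring stands alone, with the rest of the core of compound 1 kept. Placing (4-methylphenyl)sulfonyl there in place of 3-chlorophenyl gives a number 16.7 percentage points higher from compound 1 to compound 3 (beyond the scatter), so this position alone can move the read-out by a modest amount beyond the scatter. Nothing given here bears on the reason for this rise.

Going by these compounds alone, the single step cannot separate the contribution of the sulfonyl link from that of the changes on the aromatic ring, since the chlorine leaves and the methyl enters in the same exchange. It also leaves open how an acetyl group, a methylsulfonyl group or a plain phenylsulfonyl group on that nitrogen would read.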